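The compounds below may be only part of what the source reports. "The series", "measured", "known", "first", "only" and "open" are said of these compounds alone.

Of the compounds shown here, two have numbers so far in a functional assay on HL-60 cells (Homo sapiens) for antiproliferative activity, read by MTT assay; a lower number here means a stronger inhibitor, a higher number a weaker inhibitor. Compound 1 `CCS(=O)(=O)Nc1ccc(Oc2ccc(F)cc2)c(-c2cn(C)c(=O)c3cncn23)c1` gives 45 nM and compound 2 `Cn1cc(-c2cc(NS(C)(=O)=O)ccc2Oc2ccc(Br)cc2)n2cncc2c1=O` gives 230 nM. Compound 1 therefore holds the lower of the two numbers, marking it as the stronger inhibitor, and the gap between them lies beyond the usual scatter.

The next compound to follow is compound 3 `CCS(=O)(=O)Nc1ccc(Oc2cc(C)ccc2F)c(-c2cn(C)c(=O)c3cncn23)c1`, which has not yet been measured. Starting from compound 1, it carries 2-fluoro-5-methylphenyl in place of 4-fluorophenyl on an oxygen on an aromatic ring. For the measured compounds named here, no two measured compounds differ in one place only, so no measured step speaks directly to this change, and any forecast has to stay broad.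

Going by the values given here, with only two values to go on, a small loss in this assay is expected, possibly none beyond the scatter. Compound 1 at 45 nM is the lowest number seen so far, which leaves a move upward as the more likely direction. The expected size of the change is a 1.6-fold higher number from compound 1 to compound 3 (0.19 log units; within the scatter). For compound 3 the estimated value is 70 nM, within an expected range of 20 nM to 250 nM.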

Compound 3, half-maximal inhibitory concentration: 270 nM
Beside the measured number, compound 3's estimate is 3.9-fold (0.59 log units) below it, and the stated range ends below it.
By their numbers in this assay, from the lowest: compound 1; then compounds 2 and 3 (each within the scatter of the next).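

In this assay the only difference between the two compounds is the aryl group on the oxygen, and replacing 4-fluorophenyl with 2-fluoro-5-methylphenyl gives a 6.0-fold higher number from compound 1 to compound 3 (0.78 log units; beyond the scatter) and so a weaker inhibitor. For the compounds shown here, this is the first direct sign that the group at this place matters, since the shared core and the ethyl sulfonamide stay the same while the number moves beyond the scatter. There is no independent evidence on why this swap weakens the compound, so the result records an effect without an explanation.

The change also does two things at once: the fluorine has a different number in the group's name, and a methyl group is added, so this single step cannot show whether one of these alone accounts for the loss or both are needed. It also leaves open how this assay would respond to other groups at this place, such as a plain phenyl ring or a phenyl ring carrying a methoxy group or an amine.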